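Adding a chloro to the phenyl group of compound 3

The compounds below may be only part of what the source reports. "The series", "measured", "known", "first", "only" and "open" are said of these compounds alone.

Three measured compounds share one core: compound 1 `Cc1ccc(NC(=O)/C=C/c2ccccc2)c(C(N)=O)c1`, compound 2 `NC(=O)c1cc(Br)ccc1NC(=O)/C=C/c1ccccc1` and compound 3 `NC(=O)c1cc(I)ccc1NC(=O)/C=C/c1ccccc1`. In a functional assay on SK-MEL-5 cells (Homo sapiens) for inhibition, read by sulforhodamine B assay, with a stated time of 48 h (on this read-out lower numbers stand for stronger inhibition of growth and higher numbers for weaker inhibition of growth), compound 1 gives 1010 nM, compound 2 gives 435 nM and compound 3 gives 383 nM. Compound 3 therefore sits level with compound 2, as a 1.1-fold lower number from compound 2 to compound 3 (0.06 log units; within the scatter) stays within the scatter. Both lie clearly lower than compound 1.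

The next compound is compound 4 `NC(=O)c1cc(I)ccc1NC(=O)/C=C/c1ccccc1Cl`, which turns phenyl to 2-chlorophenyl: chloro in place of hydrogen on an aromatic carbon. Put simply, this is chloro in place of hydrogen on an aromatic carbon.

Among the compounds with values here, no measured step touches this phenyl group, so the evidence is only indirect. The closest guide is how far swapping one group for another moved the number elsewhere on the core. Both a 2.3-fold lower number from compound 1 to compound 2 (0.37 log units; beyond the scatter) and a 2.6-fold lower number from compound 1 to compound 3 (0.42 log units; beyond the scatter) were modest, while the bromo to iodo swap changed nothing measurable. The data give no direction for a new chloro, so a modest step at most is expected, and quite possibly none beyond the scatter. The expected step, a 1.2-fold lower number from compound 3 to compound 4 (0.06 log units; within the scatter), is an estimate resting on those sizes alone. For compound 4 the estimated value in this assay is 330 nM, with an expected range from 110 nM to 950 nM.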

Compound 4, concentration for 50% growth inhibition: 367 nM
Compound 4: the middle estimate sits 1.1-fold (0.05 log units) below what was measured; low and high end bracket the measured number.
By their numbers in this assay, from the lowest: compounds 4, 3 and 2 (each within the scatter of the next); then compound 1.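

Within the data shown here, this is the first measured change on the phenyl group, a part of the molecule that the earlier compounds left untouched. In this assay, phenyl to 2-chlorophenyl gives a 1.0-fold lower number from compound 3 to compound 4 (0.02 log units; within the scatter), so a chloro on an aromatic carbon, ortho to a large group, is tolerated here: the two compounds cannot be told apart, and growth inhibition is kept with neither a gain nor a loss that can be distinguished. No measurement of any property bears on this result, so it stands as a plain observation without an explanation.

On these data alone, one chloro at one place says little about the rest of this phenyl group, and it remains open whether a methoxy, an amine or a carboxylic acid there would hold the number or shift it, and what the same chloro would do elsewhere on the ring. Equally open, as far as these compounds go, is what a nitrile in place of the primary amide would do, and whether the 2-chlorophenyl group would behave the same way with bromo or methyl in place of iodo on the shared core.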